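The compounds below may be only part of what the source reports. "The series", "measured", "known", "first", "only" and "open" are said of these compounds alone.

Measured so far in a functional assay on the whole organism (stomach) with Rattus norvegicus as the target; on this read-out higher numbers stand for an effect only at larger amounts of compound and lower numbers for an effect already at smaller amounts:
Compound 1, `C/N=C(\S)NCCCCCn1nc(-c2ccccc2)ccc1=O`: 35.3 mg/kg.
Compound 2, `C/N=C(/NC#N)NCCCCCCn1nc(-c2ccccc2)ccc1=O`: a limit of the assay, > 100 mg/kg.
Compound 3, `CCC/N=C(/NC#N)NCCCCCn1nc(-c2ccccc2)ccc1=O`: a limit of the assay, > 100 mg/kg.

Compound 3 stands only at a limit in this assay, and it is the same limit at which compound 2 sits (the limit of > 100 mg/kg in this assay, at which 2 of the 3 values shown sit). The steps away from compound 1 are an at least 2.8-fold higher number from compound 1 to compound 3 (0.45 log units; beyond the scatter) and an at least 2.8-fold higher number from compound 1 to compound 2 (0.45 log units; beyond the scatter). Between the two limit compounds the step is a step that the two limits leave unreadable from compound 2 to compound 3.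

Compound 4, `CC/N=C(/NC#N)NCCCCCCn1nc(-c2ccccc2)ccc1=O`, differs from compound 3 by a group of 9 heavy atoms (5 carbon, 4 nitrogen; no ring) in place of a group of 9 heavy atoms (5 carbon, 4 nitrogen; no ring), on a saturated chain carbon, five bonds along the chain from an aromatic nitrogen; the two have the same atoms, joined differently. Within the data shown here, the step that bears on this change is the one from compound 2 to compound 3, which the two limits leave unreadable; both of its ends sit at the limit, and compound 4 carries the same groups as compound 3 with the chain lengthened by one and the alkyl on the imine nitrogen shortened by one. Nothing in the measured steps points to a readable step in this assay in either direction, so compound 4 is expected to sit at the limit as well, though a number cannot be ruled out.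

Compound 4 is expected at 150 mg/kg, with a range of 60 mg/kg to 400 mg/kg. This estimate means a step that the limit leaves unreadable from compound 3 to compound 4.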

Compound 4, dose for half-maximal effect: > 100 mg/kg
Compound 4 gave a limit, no number (the forecaster's own chance of this, stated with the estimate: 75%); the middle value does not contradict the limit.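

In this assay, compound 4 gives a limit and not a number, and with the same atoms joined differently from compound 3, this rearrangement does not bring a nitrile-bearing compound off that limit: the limit of > 100 mg/kg in this assay, at which 3 of the 4 values shown sit.

Among these compounds, the one readable step is an at least 2.8-fold higher number from compound 1 to compound 4 (0.45 log units; beyond the scatter), which gives a third nitrile-bearing compound standing apart from the sulfur-bearing group of compound 1, with none of the three going against this. The steps among compound 2, compound 3 and compound 4 cannot be read: both ends of each sit at the limit, so no order of chain length or alkyl size follows from them.

Open, as far as these compounds go, is whether the nitrile-bearing compounds differ from one another at all, and whether the sulfur-bearing group keeps a number on the longer chain carried by compound 2 and compound 4. Also open, from the compounds shown here alone, is what an amine or a carboxylic acid in place of the nitrile would give in this assay, and whether a still longer chain would change the picture.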